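The compounds below may be only part of what the source reports. "The series", "measured", "known", "first", "only" and "open" are said of these compounds alone.

In a functional assay on MDA-MB-468 cells (Homo sapiens) for antiproliferative activity, read by WST assay, with a stated time of 3 days (on this read-out higher numbers stand for weaker inhibition and lower numbers for stronger inhibition), compound 1, `N#Cc1cc(=O)[nH]c(=O)n1[C@@H]1O[C@H](CO)[C@@H](O)[C@H]1O`, gives > 50000 nM, which is a limit of the assay and not a number. Compound 2, `O=c1cc(I)n([C@@H]2O[C@H](CO)[C@@H](O)[C@H]2O)c(=O)[nH]1`, gives > 50000 nM, and this too is only a limit. Among the measured compounds shown here, compound 2 therefore has no exact place on the scale, and the only other value shown for comparison is also a limit.

Compound 3, `[N-]=[N+]=Nc1cc(=O)[nH]c(=O)n1[C@@H]1O[C@H](CO)[C@@H](O)[C@H]1O`, has azido in place of iodo on an aromatic carbon, the same carbon that carries the cyano group in compound 1: azido in place of iodo on an aromatic carbon. For the measured compounds named here, the one measured step that bears on this change is a step that the two limits leave unreadable from compound 1 to compound 2, so it offers no size to carry over. What remains is the limit of > 50000 nM in this assay, at which 2 of the 2 values shown sit. Because the limit of > 50000 nM in this assay, at which 2 of the 2 values shown sit, is all the data show for this carbon, the expectation in this assay is no step beyond the usual scatter, in either direction, and another limit is the likeliest outcome. The estimated change is a number no higher from compound 2 to compound 3 (the limit leaves the size open). For compound 3 the expected value is about 50000 nM, with an estimated range from 15000 nM to 100000 nM.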

Compound 3, half-maximal inhibitory concentration: > 50000 nM
Compound 3 gave a limit, no number; the forecaster's own chance of this, stated with the estimate: 70%; the middle value sits exactly at the limit.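

In this assay compound 3 gives > 50000 nM, which is again a limit and not a number. The steps among compound 1, compound 2 and compound 3 therefore cannot be read. The compounds shown leave open whether swapping the group on this carbon changes antiproliferative activity at all, and how strongly any of the three inhibits.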